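The source may hold more compounds than are shown below. What is called first, only, known or untested is meant among the compounds shown, and "the series" means these compounds.

Three compounds of this series have numbers in a functional assay on A549 cells (Homo sapiens) for cytotoxicity, read by MTT assay, with a stated time of 72 h; on this read-out higher numbers stand for weaker inhibition and lower numbers for stronger inhibition. Compound 1 `CN(C)CCn1cnnc1-c1cc(Oc2ccc(NC(=O)N/N=C/c3cccc(Cl)c3Cl)cc2F)ccn1` gives 1090 nM, the lowest of the three. Compound 2 `CN(C)CCn1cnnc1-c1cc(Oc2ccc(NC(=O)N/N=C/c3ccc(O)c(F)c3)cc2F)ccn1` gives 13400 nM, and compound 3 `CN(C)CCn1cnnc1-c1cc(Oc2ccc(NC(=O)N/N=C/c3ccc(O)cc3)cc2F)ccn1` gives 3560 nM. Both measured steps away from compound 1 replace the 2,3-dichlorophenyl on the carbon with a double bond to nitrogen: a 12-fold higher number from compound 1 to compound 2 (1.09 log units; beyond the scatter), and a 3.3-fold higher number from compound 1 to compound 3 (0.51 log units; beyond the scatter). Between the two replacing groups, a 3.8-fold lower number from compound 2 to compound 3 (0.58 log units; beyond the scatter).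

Compound 4 `COc1ccc(/C=N/NC(=O)Nc2ccc(Oc3ccnc(-c4nncn4CCN(C)C)c3)c(F)c2)c(OC)c1` has not yet been measured. Its change from compound 1 is 2,4-dimethoxyphenyl in place of 2,3-dichlorophenyl on a carbon with a double bond to nitrogen. The two replacements of the 2,3-dichlorophenyl seen so far both moved the number up, one by a modest step and one by a large one, and neither went the other way. On that basis a higher number is expected for compound 4 in this assay, most likely of modest size, with the large step to compound 2 setting the upper edge of what is plausible. The expected step is a 3.2-fold higher number from compound 1 to compound 4 (0.51 log units; beyond the scatter). The estimate for compound 4 is 3500 nM, with a range from 1200 nM to 12000 nM.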

Compound 4, half-maximal inhibitory concentration: 2820 nM
The estimate for compound 4 lay 1.2-fold (0.09 log units) above the measured number; measured number inside the range.
By their numbers in this assay, from the lowest: compound 1; then compounds 4 and 3 (each within the scatter of the next); then compound 2.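

In this assay, a third replacement of the 2,3-dichlorophenyl also raises the number, a 2.6-fold higher number from compound 1 to compound 4 (0.41 log units; beyond the scatter), which shows that the rise does not need a hydroxy group on the ring and leaves compound 1 lowest of the four. The 2,4-dimethoxyphenyl and the 4-hydroxyphenyl cannot be told apart, a 1.3-fold lower number from compound 3 to compound 4 (0.10 log units; within the scatter), whereas the 3-fluoro-4-hydroxyphenyl stays clearly separate, a 4.8-fold lower number from compound 2 to compound 4 (0.68 log units; beyond the scatter). Nothing available gives a reason for these differences.

The compounds shown leave open whether a single chlorine, as in a 2-chlorophenyl or a 3-chlorophenyl, would keep the number of compound 1. Also open, going by these compounds, is how a ring carrying an amine or a carboxylic acid would read at this position.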